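Solubility after a 3-cyanophenyl swap on compound 2

This account rests on a few compounds, and the source may have more. Where it says the series, first, only, none or still open, it means among the compounds named here.

Two related compounds share one core and differ in a single group. In a physicochemical assay for solubility (a lower number here means a less soluble compound, a higher number a more soluble compound), compound 1 `CNC(=O)c1cc(C(=O)NC2CC2)cn(Cc2cccc3cn[nH]c23)c1=O` gives >= 181 ug/mL, and this is a limit of the assay, not a number. Compound 2 `CNC(=O)c1cc(C(=O)NC2CC2)cn(Cc2cccc3c2CCN3)c1=O` gives >= 184 ug/mL, which is likewise a limit.

Compound 3 `CNC(=O)c1cc(C(=O)NC2CC2)cn(Cc2cccc(C#N)c2)c1=O` has not been measured yet. It carries 3-cyanophenyl in place of 2,3-dihydro-1H-indol-4-yl on a saturated chain carbon bound to an aromatic nitrogen.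

Among the compounds with values here, only one measured step bears on this change, and it swaps a group at the same place. That step runs a step that the two limits leave unreadable from compound 1 to compound 2. It therefore offers no size to carry over, and any forecast for this assay must stay cautious. With so little to lean on, the expectation is a small fall at most, and quite possibly nothing beyond the usual scatter of repeated measurements. The expected change is an at least 1.2-fold lower number from compound 2 to compound 3 (0.08 log units; that floor lies within the scatter). For compound 3 the estimated solubility is 150 ug/mL, with an expected range from 50 ug/mL to 200 ug/mL.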

Compound 3, solubility: >= 148 ug/mL
Compound 3: only a limit was reported; the forecaster's own chance of this, stated with the estimate: 45%; the middle value is on the limit's open side.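

In this assay compound 3 gives >= 148 ug/mL, which is a limit of the assay and not a number. Within the data shown here, compound 1 and compound 2 also stand at limits, and no step among compound 1, compound 2 and compound 3 can be read. From the compounds shown here alone, how far each compound's solubility lies past its limit, and whether the three differ at all, stays open.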